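From methoxy to propargyloxy: a single change to compound 1

The compounds below may be only part of what the source reports. "The series", "measured", "known", "first", "only" and "open" are said of these compounds alone.

Compound 1 `COc1ccc([C@@H]2CC(=O)c3cc(CC=C(C)C)c(OC)cc3O2)cc1`: 58%
Compound 2 `COc1ccc([C@@H]2C/C(=N/OCc3cn(-c4cc(OC)c(OC)c(OC)c4)nn3)c3cc(CC=C(C)C)c(OC)cc3O2)cc1`: 36%

Both values come from a functional assay on PC-3 cells (Homo sapiens) for inhibition, read by sulforhodamine B assay, with a stated time of 48 h, tested at 50 uM; on this read-out higher numbers stand for more inhibition of growth at the one concentration tested and lower numbers for less inhibition of growth. Compound 1 stands highest of the two, and compound 2 sits lower by a gap beyond the usual scatter of this kind of measurement.

The next molecule to be tested is compound 3 `C#CCOc1ccc([C@@H]2CC(=O)c3cc(CC=C(C)C)c(OC)cc3O2)cc1`. It keeps the core of compound 1 and changes one place: ethynyl in place of hydrogen on a saturated chain carbon bound to an oxygen on an aromatic ring. In words, an ethynyl replaces a hydrogen on a saturated chain carbon bound to an oxygen on an aromatic ring, so a methoxy becomes a propargyloxy.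

Going by the values given here, no two measured compounds differ in one place only, so there is no direct guide to the size of this step. Compound 2, at 36%, differs from compound 1 in more than one place and offers only a weak hint. The expected result in this assay is a small fall, a number 8 percentage points lower from compound 1 to compound 3 (within the scatter), which would stay within the scatter. Compound 3 is estimated at 50%, with an expected range from 30% to 70%.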

Compound 3, percent growth inhibition at one concentration: 52%
The estimate for compound 3 lay 2 percentage points below the measured number; the range from low to high includes it.
By their numbers in this assay, from the lowest: compound 2; then compounds 3 and 1 (each within the scatter of the next).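

Going by these compounds alone, this is the first step that changes a single place, so it can be read directly. In this assay, turning the methoxy into a propargyloxy gives a number 6 percentage points lower from compound 1 to compound 3 (within the scatter) and so leaves no difference that can be told from the usual spread of repeated measurements; on this one reading, the saturated chain carbon bound to an oxygen on an aromatic ring accepts an ethynyl in place of a hydrogen without a clear loss of growth inhibition. Nothing in the data explains why the number holds, so the result stands as an observation only.

The compounds shown leave open whether this holds for other groups at the same place, such as a longer chain like butyl, a benzyl or a chain ending in a carboxylic acid or an amine, or a plain hydroxyl in place of the methoxy. They also leave open whether compound 1 and compound 3 would still match at other concentrations, since a single-concentration reading gives no full dose-response curve.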